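The source may hold more compounds than are shown below. What is called first, only, known or untested is meant among the compounds shown, and "the series" means these compounds.

Of the compounds shown here, three that share one core have been measured in a functional assay, tested at 400 ug/mL; on this read-out lower numbers stand for a weaker effect and higher numbers for a stronger effect at the one concentration tested. Compound 1 `N#CC1=C(N)OC(c2c[nH]c3ccccc23)=C(C#N)C1c1ccccc1` gives 26.7%. Compound 2 `CN(C)c1ccc(C2C(C#N)=C(N)OC(c3c[nH]c4ccccc34)=C2C#N)cc1` carries a dimethylamino group on an aromatic carbon where compound 1 carries hydrogen, and in this assay compound 2 gives 26.7%. That is no change at the digits printed from compound 1 to compound 2 (within the scatter). Compound 3 `COc1cc(Br)c(C2C(C#N)=C(N)OC(c3c[nH]c4ccccc34)=C2C#N)cc1OC`, with yet another set of groups on that same ring, gives 26.7% in this assay. Compound 2 thus stands level with both of its neighbours at the digits shown, and nothing among these three values sets one compound apart from another.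

Compound 4 `Cc1ccc(C2C(C#N)=C(N)OC(c3c[nH]c4ccccc34)=C2C#N)cc1` is the next step from compound 2: methyl in place of dimethylamino on an aromatic carbon. Within the data shown here, the one measured step that touches this position, from hydrogen to dimethylamino, produced no change within the scatter, and compound 3 with other groups on that ring sits at the same level. The change to compound 4 is therefore expected to leave the read-out where it is, so that a number 0.3 percentage points higher from compound 2 to compound 4 (within the scatter) is expected to be no step beyond the scatter. Compound 4 is estimated at 27%, within a range from 17% to 37%.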

Compound 4, a percentage reported as activity, at one concentration (the size of the read-out at that concentration, not a potency): 8.5%
Beside the measured number, compound 4's estimate is 18.5 percentage points above it, outside the stated range (below it).
By their numbers in this assay, from the lowest: compound 4; then compounds 1, 2 and 3 (each within the scatter of the next).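

In this assay, this position is not indifferent after all: methyl in place of dimethylamino gives a number 18.2 percentage points lower from compound 2 to compound 4 (beyond the scatter), and methyl in place of hydrogen gives a number 18.2 percentage points lower from compound 1 to compound 4 (beyond the scatter). Hydrogen and dimethylamino read level here, so the lower number appears only with methyl and does not follow the heavy-atom count of the group on this carbon. Nothing available bears on why methyl behaves differently.

The compounds shown leave open whether this lower number belongs to methyl alone or would also appear with an ethyl group, a chlorine or a hydroxyl group in the same place. They also leave open whether methyl would have the same effect at another carbon of this ring.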